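The source may hold more compounds than are shown below. What is called first, only, known or untested is meant among the compounds shown, and "the series" means these compounds.

Values in a functional assay on M21 cells (Homo sapiens) for antiproliferative activity, read by sulforhodamine B assay, with a stated time of 48 h; a lower number here means a stronger inhibitor, a higher number a weaker inhibitor:
Compound 1 `Cc1cccc(NS(=O)(=O)c2ccc(N3CCNC3=O)cc2)c1`: 69 nM
Compound 2 `O=C1NCCN1c1ccc(S(=O)(=O)Nc2ccc(F)cc2)cc1`: 230 nM
Compound 3 `CC(C)(C)c1ccc(NS(=O)(=O)c2ccc(N3CCNC3=O)cc2)cc1`: > 1000 nM (a limit of the assay, not a number)

For compound 3, this assay reports only a limit, > 1000 nM. This limit gives a bound, but no exact reading from which to start.

The unmeasured compound 4 `O=C1NCCN1c1ccc(S(=O)(=O)Nc2ccc(Cl)cc2)cc1` has chloro in place of tert-butyl on an aromatic carbon.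

Among the compounds with values here, two measured steps bear on this change. The closer one is an at least 4.3-fold higher number from compound 2 to compound 3 (0.63 log units; beyond the scatter), where tert-butyl replaced fluoro at the same spot, and the number rose by a margin beyond the scatter. Compound 4 also loses the tert-butyl, so this step is expected to run largely in reverse. The other step, a 3.3-fold higher number from compound 1 to compound 2 (0.52 log units; beyond the scatter), is modest and shows that changing the group on this outer ring can shift the number. It also suggests that compound 4 need not match compound 2 exactly, even though compound 2, at 230 nM, is the best guide.

A move toward a lower number, meaning a stronger inhibitor, is therefore expected. The estimated change is an at least 4.0-fold lower number from compound 3 to compound 4 (0.60 log units; beyond the scatter). The expected value for compound 4 is 250 nM, with an estimated range from 80 nM to 800 nM.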

Compound 4, half-maximal inhibitory concentration: 90 nM
Compound 4: middle estimate off by 2.8-fold (0.44 log units), on the high side; the measured number falls inside the stated range.
By their numbers in this assay, from the lowest: compounds 1 and 4 (each within the scatter of the next); then compound 2. At a limit, above all of these: compound 3.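

In this assay, this position, para to a large group, proves able to move the number in both directions, and not only upward as the earlier step from fluoro to tert-butyl showed: chloro in place of fluoro gives a 2.6-fold lower number from compound 2 to compound 4 (0.41 log units; beyond the scatter), a modest gain between two small halogens, while chloro in place of tert-butyl gives an at least 11-fold lower number from compound 3 to compound 4 (1.04 log units; beyond the scatter). Compound 4 also draws level with the 3-methylphenyl compound, with a 1.3-fold higher number from compound 1 to compound 4 (0.12 log units; within the scatter), so 4-chlorophenyl and 3-methylphenyl on the sulfonamide nitrogen cannot be told apart in this assay. The large step is only a bound, as compound 3 stands at a limit of the assay and not at a number: the limit of > 1000 nM in this assay, at which 1 of the 4 values shown sits.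

Going by these compounds, whether the gain seen with chloro extends to bromo, methoxy, an amine or a carboxylic acid on this same aromatic carbon stays open. Also open, on these data alone, is whether the group or its place on the ring matters more, a question that a 4-methylphenyl or a 3-chlorophenyl on the sulfonamide nitrogen would address.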